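The source may report more compounds than this note shows. Statements on the series, on what has been measured and on what is new or still open speak of the compounds shown alone.

Compound 1 `Nc1nc2cc(-c3nn(CCCCCC(=O)NO)c4ncnc(N)c34)ccc2o1`: 34200 nM. Compound 2 `Nc1ncnc2c1c(-c1cnc3[nH]ccc3c1)nn2CCCCCCC(=O)NO`: 26300 nM.

In a functional assay on Hep 3B2 cells (Homo sapiens) for inhibition, read by MTT assay, with a stated time of 72 h (on this read-out lower numbers stand for stronger inhibition and higher numbers for weaker inhibition), compound 2 stands at the lower end of the two numbers shown, though compound 1 lies within the usual scatter of it, so the two cannot be told apart. Compound 3 `Nc1ncnc2c1c(-c1cnc3[nH]ccc3c1)nn2CCCCCCCCC(=O)NO` differs from compound 2 by 2-(hydroxycarbamoyl)ethyl in place of hydroxycarbamoyl on a saturated chain carbon, six bonds along the chain from an aromatic nitrogen. Within the data shown here, no step between measured compounds that differ in one place exists here, so the effect of lengthening the chain rests on no measured example. The step of a 1.3-fold lower number from compound 2 to compound 3 (0.12 log units; within the scatter) is expected to stay close to the scatter, if anything toward a somewhat lower number. Compound 3 is estimated at 20000 nM, with a range from 7000 nM to 60000 nM.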

Compound 3, half-maximal inhibitory concentration: 8390 nM
For compound 3 the middle estimate is 2.4-fold (0.38 log units) above the measured one; measured number inside the range.
By their numbers in this assay, from the lowest: compound 3; then compounds 2 and 1 (each within the scatter of the next).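

In this assay, among these compounds, the length of the chain carrying the hydroxycarbamoyl end proves to matter at this position: the change gives a 3.1-fold lower number from compound 2 to compound 3 (0.50 log units; beyond the scatter) and is the first single change here that can be read. This is one pair, so it shows a real step but not yet a pattern. Nothing available explains the step.

From the compounds shown here alone, whether a longer chain would lower the number further remains open. So does whether an amine or a carboxylic acid could replace the hydroxycarbamoyl end on this chain.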